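The compounds below may be only part of what the source reports. "The series", "measured", "known", "first", "only" and "open" are said of these compounds alone.

Measured compounds:
compound 1, `COc1cc(Cl)cc(/C=C/C(=O)c2ccc(Br)cc2)c1O` — 26.3%
compound 2, `COc1cccc(C(=O)/C=C/c2cc(Br)ccc2O)c1` — 28.3%
compound 3, `Cc1ccc(C(=O)/C=C/c2cc(F)cc(F)c2O)cc1` — 35.3%

Three chalcone-type compounds were tested in a functional assay on MCF7 cells (Homo sapiens) for antiproliferative activity, read by sulforhodamine B assay, with a stated time of 72 h, tested at 30 uM; a lower number here means a stronger effect, a higher number a weaker effect of the compound at the concentration tested. Compound 1 gives 26.3% in this assay, compound 2 gives 28.3% and compound 3 gives 35.3%. The number of compound 1 is the lowest of the three shown, but this says little: compound 2 is its nearest neighbour and compound 3 its farthest, and both lie within the usual scatter of compound 1, so no order among the three can be claimed from these values alone.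

The account now follows a single change made to compound 1. The new compound, compound 4, has the structure `COc1cc(Br)cc(/C=C/C(=O)c2ccc(Br)cc2)c1O`. It differs from compound 1 as follows: bromo in place of chloro on an aromatic carbon. Everything else in the shared core of compound 1 is kept, including the methoxy group and the hydroxy group on the same ring.

For the measured compounds named here, no pair of measured compounds here differs in just one place, so no measured step can guide the expectation. The change is small in what is counted, one halogen for another of the same kind of substitution, and nothing in the three measured compounds points in a particular direction for it. The step of a number 1.3 percentage points lower from compound 1 to compound 4 (within the scatter) is therefore expected to be small, essentially none beyond the scatter, in this assay. Compound 4 is accordingly expected to give about 25%, with a likely range from 14% to 38%.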

Compound 4, a percentage reported as activity, at one concentration (the size of the read-out at that concentration, not a potency): 48.3%
The estimate for compound 4 lay 23.3 percentage points below the measured number, outside the stated range (above it).
By their numbers in this assay, from the lowest: compounds 1, 2 and 3 (each within the scatter of the next); then compound 4.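

In this assay, the exchange of one halogen for another on this aromatic carbon, meta to a methoxy group and para to a hydroxy group, is not a silent one: bromo in place of chloro brings a number 22 percentage points higher from compound 1 to compound 4 (beyond the scatter) and so moves the read-out towards a weaker effect at the concentration tested. For the compounds shown here, the three earlier compounds could not show this, since their numbers lay within the scatter of one another and no two of them differed in just one place; this pair, with everything else in the shared core kept, is the first evidence that the read-out responds to the identity of the halogen at this position. Nothing among the data shown accounts for the size or direction of this step.

A single pair cannot tell whether the same exchange would bring a similar step in another compound or at another place on the ring. From the compounds shown here alone, it also remains open how the read-out would respond to an amine, a nitrile or a carboxylic acid on this aromatic carbon in place of either halogen.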